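A few compounds are considered here, and "the series" means these few. Any claim that something is new, unique, unknown or untested is made for them only; others in the source may bear on it.

Of the compounds shown here, three sharing one core have been read in an ADME assay on cells (Hepatocyte, Homo sapiens) for metabolic stability, with a stated time of 30 min; on this read-out lower numbers stand for a less stable compound and higher numbers for a more stable compound. With an amino group on a saturated ring carbon, compound 1 (`NC1CCC(CN2CCN(c3cc(=O)c4cc(C(F)(F)F)cc([N+](=O)[O-])c4s3)CC2)CC1`) gives 83.6%. With ((pyridin-4-yl)carbonyl)oxy at that place, compound 2 (`O=C(OC1CCC(CN2CCN(c3cc(=O)c4cc(C(F)(F)F)cc([N+](=O)[O-])c4s3)CC2)CC1)c1ccncc1`) gives 1%. That replacement amounts to a number 82.6 percentage points lower from compound 1 to compound 2 (beyond the scatter). With ((4-methylphenyl)carbonyl)oxy instead, compound 3 (`Cc1ccc(C(=O)OC2CCC(CN3CCN(c4cc(=O)c5cc(C(F)(F)F)cc([N+](=O)[O-])c5s4)CC3)CC2)cc1`) gives 9.7%, and this replacement amounts to a number 73.9 percentage points lower from compound 1 to compound 3 (beyond the scatter). Compound 3 therefore stands far under compound 1 and cannot be told apart from compound 2, the exchange between these two being a number 8.7 percentage points higher from compound 2 to compound 3 (within the scatter).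

Compound 4 (`O=C(OC1CCC(CN2CCN(c3cc(=O)c4cc(C(F)(F)F)cc([N+](=O)[O-])c4s3)CC2)CC1)C1CCCCC1`) differs from compound 3 in one place: cyclohexyl in place of 4-methylphenyl on a carbonyl carbon. In short, cyclohexyl stands in place of 4-methylphenyl on a carbonyl carbon. The two large steps away from compound 1 both introduced a carbonyl-oxy group, which compound 4 keeps. Going by the values given here, the one measured exchange on that carbonyl carbon, a number 8.7 percentage points higher from compound 2 to compound 3 (within the scatter), is the closest precedent, and it stayed small. Among the compounds with values here, no measured compound has a non-aromatic ring there, so the precedent is imperfect. The expected change is a number 1.7 percentage points lower from compound 3 to compound 4 (within the scatter), which means no step beyond the scatter is anticipated in this assay. For compound 4 the estimated value is 8%, with an expected range of 1% to 25%.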

Compound 4, percent of the compound remaining: 2.8%
Compound 4: middle estimate off by 5.2 percentage points, on the high side; the measured number falls inside the stated range.
By their numbers in this assay, from the lowest: compounds 2, 4 and 3 (each within the scatter of the next); then compound 1.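

In this assay a non-aromatic ring on the carbonyl carbon joins the two aromatic rings, and the read-out does not separate it from either of them: the change is a number 6.9 percentage points lower from compound 3 to compound 4 (within the scatter) and a number 1.8 percentage points higher from compound 2 to compound 4 (within the scatter). Compound 4 also repeats the large drop seen with the other two (carbonyl)oxy groups, with a number 80.8 percentage points lower from compound 1 to compound 4 (beyond the scatter), so pyridin-4-yl, 4-methylphenyl and cyclohexyl on this carbonyl carbon all leave the compound far under compound 1 while staying within the scatter of one another. Nothing measured here gives a reason for this result.

The compounds shown leave open whether an open-chain group on the same carbonyl carbon, such as methyl or tert-butyl, or a ring carrying an amine or a carboxylic acid, would also stay within the scatter of compound 2, compound 3 and compound 4. They also leave open whether an amide, with nitrogen in place of the oxygen next to the carbonyl group, would fall as far from compound 1 as the three (carbonyl)oxy compounds do.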